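The source may report more compounds than this note shows. Statements on the series, on what has been measured and on what is new or still open speak of the compounds shown alone.

Among the compounds with values here, compound 1 `O=C(NCCN1CCC(O)(Cc2ccccc2)CC1)Nc1ccnc2ccoc12` is one of two compounds measured in an assay on HEK293 cells for displacement of a labelled ligand from Urotensin-2 receptor (Homo sapiens); on this read-out lower numbers stand for stronger inhibition and higher numbers for weaker inhibition. In this assay compound 1 gives 450 nM, the highest of the two numbers. Compound 2 `Cc1ccc(CC2(O)CCN(CCNC(=O)Nc3ccnc4ccsc34)CC2)cc1` gives 190 nM in this assay, a lower number than compound 1 by a margin beyond the usual scatter; since compound 2 differs from compound 1 in more than one place, only the two values themselves can be compared.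

Compound 3 `O=C(NCCN1CCC(O)(Cc2ccccc2)CC1)Nc1ccnc2sccc12` differs from compound 1 in one place: a group of 9 heavy atoms (7 carbon, 1 nitrogen, 1 sulfur; one five-membered aromatic ring with 1 hetero atom, one six-membered aromatic ring with 1 hetero atom) in place of a group of 9 heavy atoms (7 carbon, 1 nitrogen, 1 oxygen; one five-membered aromatic ring with 1 hetero atom, one six-membered aromatic ring with 1 hetero atom), on an amide-type nitrogen. The group that enters is the same bicyclic group carried by compound 2.

Within the data shown here, no measured pair isolates this exchange, so the size of the step is uncertain. Compound 3 is expected to give a somewhat lower number than compound 1 in this assay, with a step of a 1.7-fold lower number from compound 1 to compound 3 (0.24 log units; within the scatter) that may or may not exceed the scatter, because compound 2, which carries the same sulfur-containing bicycle, gives 190 nM. Compound 3 is estimated at 260 nM, within a range from 100 nM to 650 nM.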

Compound 3, half-maximal inhibitory concentration: 930 nM
Compound 3: the middle estimate sits 3.6-fold (0.55 log units) below what was measured, outside the stated range (above it).
By their numbers in this assay, from the lowest: compound 2; then compound 1; then compound 3.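

On the amide-type nitrogen of the shared core, in this assay, exchanging the oxygen-containing bicyclic group for the sulfur-containing one gives a 2.1-fold higher number from compound 1 to compound 3 (0.32 log units; beyond the scatter), a modest step but one beyond the usual scatter. Within the data shown here, this is the first step that can be read at this place, and it shows that the number responds to the bicyclic group even though the heavy-atom count, the ring types and the counts of hydrogen-bond donors and acceptors stay the same on both sides of the exchange. Nothing among the measurements shown bears on why the number rises with this exchange.

From the compounds shown here alone, whether the step would keep its size with other parts of the core changed stays open, as compound 2 differs from both compound 1 and compound 3 in more than one place. Also open, going by these compounds, is how this place would answer to a group outside this pair, such as a plain phenyl ring, a bicyclic group with a second nitrogen in its five-membered ring, or an open methoxyethyl chain on the amide-type nitrogen.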